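Chloroalkyl chain extension on the amide of compound 3

The source may report more compounds than this note shows. Statements on the series, on what has been measured and on what is new or still open speak of the compounds shown alone.

Measured so far:
compound 1, `CCCC(=O)Nc1ccc(S(=O)(=O)Oc2ccccc2C(C)C)cc1`: 6100 nM
compound 2, `CC(C)c1ccccc1OS(=O)(=O)c1ccc(NC(=O)C(C)(C)C)cc1`: 6200 nM
compound 3, `CC(C)c1ccccc1OS(=O)(=O)c1ccc(NC(=O)CCCl)cc1`: 14000 nM

In a functional assay on M21 cells (Homo sapiens) for antiproliferative activity, read by sulforhodamine B assay, with a stated time of 48 h (a higher number here means a weaker inhibitor, a lower number a stronger inhibitor), compound 3 stands at the highest of the three numbers, with a 2.3-fold higher number from compound 1 to compound 3 (0.36 log units; beyond the scatter) and a 2.3-fold higher number from compound 2 to compound 3 (0.35 log units; beyond the scatter) both modest. Compound 4, `CC(C)c1ccccc1OS(=O)(=O)c1ccc(NC(=O)CCCCl)cc1`, carries chloromethyl in place of chloro on a saturated chain carbon, two bonds along the chain from a carbonyl carbon. Among the compounds with values here, no measured step extends a chain in this way; the steps that bear on it, a 2.3-fold higher number from compound 1 to compound 3 (0.36 log units; beyond the scatter) and a 2.3-fold higher number from compound 2 to compound 3 (0.35 log units; beyond the scatter), only show that swapping the group on the carbonyl moves this assay by a modest amount. On that basis the step from compound 3 to compound 4 is expected to stay small, a 1.2-fold lower number from compound 3 to compound 4 (0.07 log units; within the scatter), in either direction. For compound 4 the estimate in this assay is 12000 nM, within 5000 nM to 28000 nM.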

Compound 4, half-maximal inhibitory concentration: 5100 nM
For compound 4 the middle estimate is 2.4-fold (0.37 log units) above the measured one; the range from low to high includes it.
By their numbers in this assay, from the lowest: compounds 4, 1 and 2 (each within the scatter of the next); then compound 3.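

In this assay, 3-chloropropyl in place of 2-chloroethyl on the carbonyl carbon gives a 2.7-fold lower number from compound 3 to compound 4 (0.44 log units; beyond the scatter), so this position responds to a change in chain length bearing chloro. With chloro in place of hydrogen, three bonds along the chain from a carbonyl carbon, there is a 1.2-fold lower number from compound 1 to compound 4 (0.08 log units; within the scatter), and 3-chloropropyl in place of tert-butyl gives a 1.2-fold lower number from compound 2 to compound 4 (0.08 log units; within the scatter), so neither change separates these compounds. No measured evidence accounts for these steps. On these data alone, whether a longer chloroalkyl chain, or an amine in place of chloro, would hold this level in this assay stays open.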